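The source may report more compounds than this note shows. Statements on the series, on what has been measured and on what is new or still open speak of the compounds shown alone.

Measured so far in a functional assay on A549 cells (Homo sapiens) for cytotoxicity, read by WST assay, with a stated time of 48 h; on this read-out lower numbers stand for stronger inhibition and higher numbers for weaker inhibition
- compound 1 `COc1ccc2[nH]cc(/C=C(\C#N)C(=O)c3c[nH]c4ccccc34)c2c1` gives 13700 nM
- compound 2 `N#C/C(=C\c1cn(Cc2ccc(Cl)cc2)c2ccc(Br)cc12)C(=O)c1c[nH]c2ccccc12` gives 24900 nM
- compound 3 `N#C/C(=C\c1c[nH]c2ccccc12)C(=O)c1c[nH]c2ccccc12` gives 22000 nM

Compound 3 lies within the scatter of both compound 1 and compound 2, so no order can be read among the three. Within the data shown here, compound 4 `N#C/C(=C\c1cn(Cc2ccc(Cl)cc2)c2ccccc12)C(=O)c1c[nH]c2ccccc12` derives from compound 3 with 4-chlorobenzyl in place of hydrogen on an aromatic nitrogen as its only change. Among the measured compounds shown here, the one measured step is a 1.6-fold higher number from compound 1 to compound 3 (0.21 log units; within the scatter) and it concerns methoxy on an aromatic carbon, not the aromatic nitrogen, so it bears on the change only loosely. Compound 2 is closer, since it carries 4-chlorobenzyl in the same place along with a bromine on the core. Compound 2 gives 24900 nM and this stays within the scatter of compound 3. No measurement isolates the 4-chlorobenzyl group alone. The expected outcome in this assay is therefore no shift beyond the scatter in either direction, with an expected 1.0-fold lower number from compound 3 to compound 4 (0.02 log units; within the scatter) as the step. Compound 4 is estimated at 21000 nM with an expected range from 9500 nM to 46000 nM for most repeat measurements.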

Compound 4, half-maximal inhibitory concentration: > 50000 nM
Compound 4 gave a limit, no number; the forecaster's own chance of this, stated with the estimate: 10%; middle value at least 2.3-fold (0.37 log units) away from the limit.
By their numbers in this assay, from the lowest: compounds 1, 3 and 2 (each within the scatter of the next). At a limit, above all of these: compound 4.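

In this assay compound 4 gives > 50000 nM, which is a limit of the assay and not a number. Among these compounds, on the aromatic nitrogen, 4-chlorobenzyl in place of hydrogen gives an at least 2.2-fold higher number from compound 3 to compound 4 (0.35 log units; beyond the scatter), the only step so far that isolates this position and the only one beyond the scatter. With 4-chlorobenzyl kept on the nitrogen, hydrogen in place of bromo on an aromatic carbon gives an at least 2.0-fold higher number from compound 2 to compound 4 (0.30 log units; that floor lies within the scatter), so the floor of this step does not separate the pair, and its true size cannot be read.

As far as these compounds go, whether a plain methyl or a longer alkyl chain on the same nitrogen would give a shift like that of 4-chlorobenzyl remains open. Also open, from the compounds shown here alone, is whether an amine or a carboxylic acid on the benzyl ring in place of chlorine would change the outcome.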